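This account rests on a few compounds, and the source may have more. Where it says the series, first, only, none or still open, it means among the compounds named here.

Compound 1 `Nc1noc2ccc(-n3nc(C(F)(F)F)cc3C(=O)Cc3ccc(-c4ccccc4S(N)(=O)=O)cc3F)cc12`, > 20000 nM
Compound 2 `CS(=O)(=O)c1ccccc1-c1ccc(CC(=O)c2cc(C(F)(F)F)nn2-c2ccc3onc(N)c3c2)c(F)c1`, > 20000 nM
Compound 3 `Nc1noc2ccc(-n3nc(C(F)(F)F)cc3C(=O)Cc3ccc(-c4ccccc4S(N)(=O)=O)cc3)cc12`, > 20000 nM

In an assay on isolated protein for inhibition of Trypsin (Homo sapiens) (on this read-out lower numbers stand for stronger inhibition and higher numbers for weaker inhibition), compound 1 gives > 20000 nM, which is a limit of the assay and not a number. Compound 2 gives > 20000 nM, likewise a limit. Compound 3 gives > 20000 nM, again a limit. All three values sit at the limit of > 20000 nM in this assay, at which 3 of the 3 values shown sit, so the numbers give no footing to rank compound 1 against either of the others.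

The step to compound 4 `COc1ccc(-n2nc(C(F)(F)F)cc2C(=O)Cc2ccc(-c3ccccc3S(N)(=O)=O)cc2F)cc1` is a group of 8 heavy atoms (7 carbon, 1 oxygen; one six-membered aromatic ring of carbon only) in place of a group of 10 heavy atoms (7 carbon, 2 nitrogen, 1 oxygen; one five-membered aromatic ring with 2 hetero atoms, one six-membered aromatic ring of carbon only), on an aromatic nitrogen: a 4-methoxyphenyl enters on an aromatic nitrogen of the five-membered aromatic ring with two nitrogens, two ring bonds from the ring atom that bears the trifluoromethyl group.

For the measured compounds named here, two measured steps bear on the series: a step that the two limits leave unreadable from compound 1 to compound 2 and a step that the two limits leave unreadable from compound 1 to compound 3. Both run between two limits, so neither has a readable size, and no compound shown offers a number to which the new change could be tied. Nothing here points to a step in this assay beyond the scatter in either direction; the most the data support is that compound 4 is expected to stay at the limit. The estimated step is a step that the limit leaves unreadable from compound 1 to compound 4. Compound 4 is estimated at 30000 nM, between 10000 nM and 100000 nM.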

Compound 4, inhibition constant: > 6000 nM
Compound 4 gave a limit, no number; the forecaster's own chance of this, stated with the estimate: 85%; the middle value is on the limit's open side.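

In this assay compound 4 gives > 6000 nM, which is a limit of the assay and not a number. Compound 1 also stands at a limit, so the step from compound 1 to compound 4 cannot be read. The compounds shown leave open whether any of them has a measurable inhibition constant, and so what the 4-methoxyphenyl change does to it.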